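Removing the fused ring from a potent inhibitor

The source may report more compounds than this note shows. Statements on the series, on what has been measured and on what is new or still open speak of the compounds shown alone.

For the measured compounds named here, compound 2 `Cc1cc(Cl)cc(-c2ccnc3cc(CN4C(=O)C5CC5C4=O)sc23)c1O[C@@H]1CCNC[C@@H]1C` gives 1.1 nM in an assay on isolated protein for inhibition of ubiquitin carboxyl-terminal hydrolase 7 (Homo sapiens), read by fluorescence, with stated times of 30 min and 1 h (a higher number here means a weaker inhibitor, a lower number a stronger inhibitor), the lowest of the two numbers known here; compound 1 `Nc1cc(-c2cc(Cl)cc3c2OC(C(=O)N2CCNCC2)C3)ccn1` gives 5600 nM in this assay, a gap well beyond the scatter. Compound 3 `Cc1cc(Cl)cc(-c2ccnc3cc(CN4C(=O)CCC4=O)sc23)c1O[C@@H]1CCNC[C@@H]1C` differs from compound 2 by a group of 7 heavy atoms (4 carbon, 1 nitrogen, 2 oxygen; one five-membered non-aromatic ring with 1 hetero atom) in place of a group of 8 heavy atoms (5 carbon, 1 nitrogen, 2 oxygen; one three-membered non-aromatic ring of carbon only, one five-membered non-aromatic ring with 1 hetero atom), on a saturated chain carbon bound to an aromatic carbon. Going by the values given here, no step between measured compounds is available for this change, so the expectation rests on compound 2 alone. Because compound 2 gives 1.1 nM, the step of a 2.3-fold higher number from compound 2 to compound 3 (0.36 log units; beyond the scatter) is expected to be small, toward a slightly weaker inhibitor, and possibly within the scatter. Compound 3 is estimated at 2.5 nM, within 0.7 nM to 10 nM.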

Compound 3, half-maximal inhibitory concentration: 2.1 nM
The estimate for compound 3 lay 1.2-fold (0.08 log units) above the measured number, within the range that was stated.
By their numbers in this assay, from the lowest: compounds 2 and 3 (each within the scatter of the next); then compound 1.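

At this position, on a saturated chain carbon bound to an aromatic carbon, 2,5-dioxopyrrolidin-1-yl in place of the group bearing the three-membered carbon ring gives a 1.9-fold higher number from compound 2 to compound 3 (0.28 log units; within the scatter) in this assay. The three-membered ring of carbon only is therefore not needed to keep the number in this range, and this assay does not separate the two compounds. Nothing available here bears on this result. From the compounds shown here alone, what a primary amine or a carboxylic acid would give in place of 2,5-dioxopyrrolidin-1-yl remains open. So does whether both carbonyl groups of that ring are needed.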